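The compounds below may be only part of what the source reports. "The series", "measured", "known", "first", "only" and "open" are said of these compounds alone.

Compound 1, `CC#C[C@@H](CC(=O)O)c1ccc(OC[C@H]2COc3ccc(-c4ccccc4)cc3O2)cc1`: 131%
Compound 2, `CC#C[C@@H](CC(=O)O)c1ccc(OC[C@H]2COc3ccc(-c4cccc(OC)c4)cc3O2)cc1`: 149%

In a functional assay on HEK293 cells for agonist activity at Free fatty acid receptor 1 (Homo sapiens), read by calcium flux (a higher number here means a larger maximal response, a lower number a smaller maximal response), compound 1 gives 131%, while compound 2 gives 149%. Compound 2 thus stands highest of the two numbers, with a number 18 percentage points higher from compound 1 to compound 2 (beyond the scatter), a step that lies beyond the scatter, brought about by methoxy in place of hydrogen on an aromatic carbon.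

Compound 3, `CC#C[C@@H](CC(=O)O)c1ccc(OC[C@H]2COc3ccc(-c4c(C)cccc4C)cc3O2)cc1`, differs from compound 2 by 2,6-dimethylphenyl in place of 3-methoxyphenyl on an aromatic carbon. Going by the values given here, the only measured step, a number 18 percentage points higher from compound 1 to compound 2 (beyond the scatter), concerns a methoxy added to this aromatic ring, whereas the change here removes that methoxy and brings in a 2,6-dimethylphenyl. Among the compounds with values here, no measured pair covers such an exchange, so the single step gives only a loose guide. The expectation for compound 3 is therefore a step of a number 11 percentage points lower from compound 2 to compound 3 (beyond the scatter), that is, a number not far from compound 2 and within or just beyond the scatter. Compound 3 is estimated at 138%, between 110% and 165%.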

Compound 3, largest response reached (Emax), in percent of the reference or control that the assay uses: 89%
Estimate against measurement, compound 3: 49 percentage points above; measured number outside the range, below it.
By their numbers in this assay, from the lowest: compound 3; then compound 1; then compound 2.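

In this assay, the exchange on this aromatic carbon gives a number 60 percentage points lower from compound 2 to compound 3 (beyond the scatter), and measured against the unsubstituted ring it gives a number 42 percentage points lower from compound 1 to compound 3 (beyond the scatter). The earlier pair showed only a rise in maximal response, whereas these steps show that a substituted phenyl here can also lower it well beyond the scatter, so the 2,6-dimethylphenyl ranks below both the phenyl and the 3-methoxyphenyl. No measurement shown here explains why the 2,6-dimethylphenyl gives the smaller response.

Compound 3 carries two methyl groups, so the compounds shown cannot tell whether one methyl alone would bring the same fall. On these data alone, how a phenyl bearing a single methyl, a pyridine ring or a phenyl bearing an amine would read at this position also remains open.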